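The compounds below may be only part of what the source reports. "The series", "measured", "known", "first", "only" and "open" are said of these compounds alone.

Measured compounds:
- compound 1 `FC(F)(F)Cc1cnc2c(Cl)c(-c3cc(Cl)c4c(ccn4CC4CC4)c3)ccn12` gives 193% in a functional assay on CHO cells for agonist activity at metabotropic glutamate receptor 2 (Homo sapiens); a lower number here means a smaller maximal response, a higher number a larger maximal response
- compound 2 `Cn1ccc2cc(-c3ccn4c(CC(F)(F)F)cnc4c3C#N)cc(Cl)c21` gives 184% in this assay

Compound 2 has the lower of the two numbers, with compound 1 only a few points higher, a gap within the scatter. Compound 3 `N#Cc1c(-c2cc(Cl)c3[nH]ccc3c2)ccn2c(CC(F)(F)F)cnc12` is unmeasured; it differs from compound 2 by hydrogen in place of methyl on an aromatic nitrogen. Among the measured compounds shown here, no step between measured compounds covers this change. The two measured values sit close together, so the expected step is small, at most a slight decrease, a number 9 percentage points lower from compound 2 to compound 3 (within the scatter), and no direction beyond the scatter is firmly expected. Compound 3 is estimated at 175%, range 140% to 205%.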

Compound 3, largest response reached (Emax), in percent of the reference or control that the assay uses: 277%
Compound 3: middle estimate off by 102 percentage points, on the low side, outside the stated range (above it).
By their numbers in this assay, from the lowest: compounds 2 and 1 (each within the scatter of the next); then compound 3.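

On the aromatic nitrogen of the five-membered ring, hydrogen in place of methyl is a large change in this assay (a number 93 percentage points higher from compound 2 to compound 3 (beyond the scatter)). Among the compounds shown here, the earlier compounds both carry a carbon substituent on this nitrogen, so only this pair shows that the maximal response depends strongly on what sits there. Nothing measured here bears on the reason for the step.

On these data alone, whether an ethyl group or an acetyl group on this nitrogen keeps the response near that of methyl or of hydrogen remains open. Also open, as far as these compounds go, is whether hydrogen on this nitrogen gives a similar step on the core of compound 1.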